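This account rests on a few compounds, and the source may have more. Where it says the series, first, only, none or still open, it means among the compounds named here.

Measured so far:
- compound 1, `CS/C(=N\O)c1ccc(Sc2cc(F)cc(C3CCOCC3)c2)cc1`: 190 nM
- compound 2, `COC1(c2csc(Sc3ccc4c(c3)OCC/C4=N\OCC#N)c2)CCOCC1`: 60 nM

In a functional assay (blood) for inhibition, with Homo sapiens as the target (a lower number here means a stronger inhibitor, a higher number a weaker inhibitor), compound 1 gives 190 nM and compound 2 gives 60 nM; compound 1 thus stands at the higher of the two numbers, with compound 2 beyond the scatter below it. Among the compounds with values here, no pair differing in one place has been measured, so no step size is known yet.

Compound 3, `C/C(=N\OC(=O)N(C)C)c1ccc(Sc2cc(F)cc(C3CCOCC3)c2)cc1`, is to be measured in this assay. It differs from compound 1 in one place: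

a group of 9 heavy atoms (5 carbon, 2 nitrogen, 2 oxygen; no ring) in place of a group of 5 heavy atoms (2 carbon, 1 nitrogen, 1 oxygen, 1 sulfur; no ring), on an aromatic carbon

Without any measured step to lean on, the expected step from compound 1 to compound 3 in this assay is estimated as small, a 1.3-fold lower number from compound 1 to compound 3 (0.10 log units; within the scatter), lying within the scatter rather than clearly in either direction. Compound 3 is therefore estimated at 150 nM, with a range from 50 nM to 500 nM.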

Compound 3, half-maximal inhibitory concentration: 2610 nM
Beside the measured number, compound 3's estimate is 17-fold (1.24 log units) below it; the measured number lies above the stated range.
By their numbers in this assay, from the lowest: compound 2; then compound 1; then compound 3.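

In this assay, within the data shown here, this place, on an aromatic carbon of a six-membered aromatic ring of carbon only and para to a large group, proves sensitive to what it carries: the replacement gives a 14-fold higher number from compound 1 to compound 3 (1.14 log units; beyond the scatter) and is the first step known. The entering group has 9 heavy atoms against 5 and 0 hydrogen-bond donors against 1, while both groups have 3 hydrogen-bond acceptors, so size and donor count change together in this one step. No measurement at hand bears on the reason for the rise.

Which of the two differences matters remains open, as a single step cannot separate them. As far as these compounds go, how a smaller or differently built group at this place would read, such as an amine or a carboxylic acid, also remains open.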